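A few compounds are considered here, and "the series" means these few. Any claim that something is new, unique, unknown or untested is made for them only; others in the source may bear on it.

Measured compounds:
- compound 1, `Cc1ccc(C(=O)Nc2cn3ncnc3c(O[C@H]3CCN(C(=O)CC(C(F)(F)F)C(F)(F)F)[C@@H](C)C3)c2C)cn1`: 8590 ng.h/mL
- compound 2, `Cc1ccc(C(=O)Nc2cn3ncnc3c(CN3CCN(C(=O)C4CCCC4)[C@@H](C)C3)c2C)cn1`: 400 ng.h/mL
- compound 3, `Cc1ccc(C(=O)Nc2cc(F)cc(CN3CCN(C(=O)C4CCCC4)[C@@H](C)C3)c2C)cn1`: 222 ng.h/mL

In an ADME assay on the whole organism (Mus musculus) for pharmacokinetics, using cassette dosing, at a dose of 2 umol/kg by the oral route (a lower number here means less compound in the circulation, a higher number more compound in the circulation at the dose given), compound 2 stands second highest of the three numbers. Its nearest neighbour is compound 3, whose value in this assay is 222 ng.h/mL and lies within the scatter of the value of compound 2; its furthest is compound 1, which in this assay gives 8590 ng.h/mL, a gap beyond the scatter.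

The unmeasured compound 4, `Cc1ccc(C(=O)Nc2cn3ncnc3c(CN3CCN(C(=O)CC(C(F)(F)F)C(F)(F)F)[C@@H](C)C3)c2C)cn1`, is compound 2 with one change: 3,3,3-trifluoro-2-(trifluoromethyl)propyl in place of cyclopentyl on a carbonyl carbon. Compound 1 carries the same 3,3,3-trifluoro-2-(trifluoromethyl)propyl group on its carbonyl carbon, and its value in this assay is the highest of the three; compound 1 differs from compound 4 in more than this one place, however, so that comparison is only a hint. On this basis an upward step beyond the scatter is expected, though a modest one. The estimate for compound 4 in this assay is 1200 ng.h/mL, with a range from 400 ng.h/mL to 4000 ng.h/mL, an expected step of a 3.0-fold higher number from compound 2 to compound 4 (0.48 log units; beyond the scatter).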

Compound 4, area under the concentration-time curve: 1310 ng.h/mL
The estimate for compound 4 lay 1.1-fold (0.04 log units) below the measured number; measured number inside the range.
By their numbers in this assay, from the lowest: compounds 3 and 2 (each within the scatter of the next); then compound 4; then compound 1.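

In this assay, the group on the carbonyl carbon bound to the ring amide-type nitrogen changes the number by itself: a 3.3-fold higher number from compound 2 to compound 4 (0.52 log units; beyond the scatter), with the rest of the structure the same. Within the data shown here, the earlier compounds gave no step in one place, so this is the first direct reading at this position, and it shows that an open-chain 3,3,3-trifluoro-2-(trifluoromethyl)propyl group can stand in place of the cyclopentyl ring without loss in this read-out. Nothing shown explains the rise.

The compounds shown do not separate the fluorines from the loss of the ring, as neither a plain 2-methylpropyl group nor a 3,3-difluorocyclopentyl group stands among them at this position. On these data alone, whether the step holds on another core also remains open, since compound 3 has no partner here carrying the 3,3,3-trifluoro-2-(trifluoromethyl)propyl group.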